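The compounds below may be only part of what the source reports. "The series", "measured", "known", "first", "only" and "open" are said of these compounds alone.

Working notes on the series. Compound 1 `COc1cc(/C=C/C(=O)c2cccc(-n3cc(-c4ccccc4)[nH]c3=O)c2)ccc1O` and compound 2 `COc1ccc(-c2cn(-c3cccc(C(=O)/C=C/c4ccc(O)c(OC)c4)c3)c(=O)[nH]2)cc1` differ only in a methoxy on an aromatic carbon, and in a functional assay on MDA-MB-231 cells (Homo sapiens) for inhibition (on this read-out higher numbers stand for weaker inhibition of growth and lower numbers for stronger inhibition of growth), compound 1 gives 3360 nM while compound 2 gives 5250 nM. That step, a 1.6-fold higher number from compound 1 to compound 2 (0.19 log units; within the scatter), is the only one measured so far, and compound 2 sits at the higher of the two numbers, though within the scatter of compound 1. Compound 3 `COc1cc(/C=C/C(=O)c2cccc(-n3cc(-c4ccc(Cl)cc4)[nH]c3=O)c2)ccc1O` is the next member; it differs from compound 2 by chloro in place of methoxy on an aromatic carbon. No measured step bears directly on chloro against methoxy at this position; the one step in hand, from hydrogen to methoxy, stayed within the scatter, so the substituent on this ring has so far shown no effect beyond the scatter in this assay. Compound 3 is therefore expected to change by a 1.3-fold lower number from compound 2 to compound 3 (0.12 log units; within the scatter), no more than the scatter, and its estimate in this assay is 4000 nM, within 1500 nM to 11000 nM.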

Compound 3, concentration for 50% growth inhibition: 3870 nM
Compound 3: middle estimate off by 1.0-fold (0.01 log units), on the high side; low and high end bracket the measured number.
By their numbers in this assay, from the lowest: compounds 1, 3 and 2 (each within the scatter of the next).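

In this assay, the change from 4-methoxyphenyl to 4-chlorophenyl gives a 1.4-fold lower number from compound 2 to compound 3 (0.13 log units; within the scatter), and chloro in place of hydrogen on the same aromatic carbon gives a 1.2-fold higher number from compound 1 to compound 3 (0.06 log units; within the scatter). Going by these compounds alone, this position has now carried hydrogen, methoxy and chloro, and no step among compounds 1, 2 and 3 lies beyond the scatter, so this read-out does not separate these three groups here. Nothing on hand offers an explanation for this result.

As far as these compounds go, whether an amine, a carboxylic acid or a longer chain such as butoxy at this position would move the number beyond the scatter remains open. The compounds shown also leave open how much the number depends on the rest of the shared core, including the hydroxy and methoxy groups on the other aromatic ring and the carbonyl.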